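A few compounds are considered here, and "the series" means these few. Any claim that something is new, unique, unknown or untested is made for them only; others in the source may bear on it.

Compound 1, `CCCCCC(=O)NCC(C)(C)CC1=C(O)C(=O)c2ccccc2C1=O`, compound 2, `CCCCCCCC(=O)NCC(C)(C)CC1=C(O)C(=O)c2ccccc2C1=O`, and compound 3, `CCCCCCCCCCCCCC(=O)NCC(C)(C)CC1=C(O)C(=O)c2ccccc2C1=O`, share one core and differ only in the length of the acyl chain on the amide. In a functional assay on KB cells (Homo sapiens) for cytotoxicity, read by resazurin assay, with a stated time of 3 days (on this read-out higher numbers stand for weaker inhibition and lower numbers for stronger inhibition), compound 1 gives 40200 nM, compound 2 gives 24600 nM and compound 3 gives 25100 nM. The change from compound 1 to compound 2 is ethyl in place of hydrogen on a saturated chain carbon, five bonds along the chain from a carbonyl carbon, and it made a step of a 1.6-fold lower number from compound 1 to compound 2 (0.21 log units; within the scatter). Compound 3 differs from compound 1 by octyl in place of hydrogen on a saturated chain carbon, five bonds along the chain from a carbonyl carbon, with a step of a 1.6-fold lower number from compound 1 to compound 3 (0.20 log units; within the scatter); the step of a 1.0-fold higher number from compound 2 to compound 3 (0.01 log units; within the scatter) likewise stays flat.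

Compound 4, `CCCCCCCCCCCCCCCC(=O)NCC(C)(C)CC1=C(O)C(=O)c2ccccc2C1=O`, has not yet been measured in this assay. It differs from compound 3 by ethyl in place of hydrogen on a saturated chain carbon, ten or more bonds along the chain from a carbonyl carbon. This is the same kind of change as that from compound 1 to compound 2, only at a different place along the chain. Because the steps of a 1.6-fold lower number from compound 1 to compound 2 (0.21 log units; within the scatter) and a 1.0-fold higher number from compound 2 to compound 3 (0.01 log units; within the scatter) both lie within the scatter, compound 4 is expected to sit close to compound 3, with an estimated step of a 1.0-fold higher number from compound 3 to compound 4 (0.02 log units; within the scatter). Compound 4 is therefore estimated at 26000 nM, between 13000 nM and 55000 nM.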

Compound 4, half-maximal inhibitory concentration: 5120 nM
Compound 4: the middle estimate sits 5.1-fold (0.71 log units) above what was measured; the whole stated range lies above it.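

In this assay the ethyl change gave a 4.9-fold lower number from compound 3 to compound 4 (0.69 log units; beyond the scatter), and it did not carry over at the same size from the shorter chain: the same change on two cores in this assay, a 1.6-fold lower number (0.21 log units; within the scatter) from compound 1 to compound 2 and a 4.9-fold lower number (0.69 log units; beyond the scatter) from compound 3 to compound 4, 3.0-fold (0.48 log units) apart, beyond the scatter of two such steps. The octyl change, with a 4.8-fold lower number from compound 2 to compound 4 (0.68 log units; beyond the scatter), likewise differed from its earlier counterpart: the same change on two cores in this assay, a 1.6-fold lower number (0.20 log units; within the scatter) from compound 1 to compound 3 and a 4.8-fold lower number (0.68 log units; beyond the scatter) from compound 2 to compound 4, 3.0-fold (0.48 log units) apart, beyond the scatter of two such steps. Taken from the shortest chain to the longest, the series comes to a 7.9-fold lower number from compound 1 to compound 4 (0.89 log units; beyond the scatter), but the drop rests on compound 4 alone, since compound 1, compound 2 and compound 3 lie within the scatter of one another, so this shows that the effect of adding chain carbons depends on the chain it is added to, and it does not show why or establish a trend with length.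

The compounds shown leave open whether a longer chain than that of compound 4 would lower the number further or reverse the drop. They also leave open how an amine or a carboxylic acid on the acyl chain would compare with these plain chains.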